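Phenyl in place of methyl on the shared core

A few compounds are considered here, and "the series" means these few. Any claim that something is new, unique, unknown or untested is made for them only; others in the source may bear on it.

Compound 3 `Cc1nc2c3ccccc3ccc2c2nc3c(ccc4ccccc43)c(C)c12` gives the highest of the three numbers in a functional assay, with a stated time of 90 s (on this read-out higher numbers stand for weaker inhibition and lower numbers for stronger inhibition), namely 195 ug/mL. Compound 2 `Cc1nc2c3ccccc3ccc2c2nc3c(ccc4ccccc43)c(-c3cccc([N+](=O)[O-])c3)c12` gives 157 ug/mL in this assay, and compound 1 `Cc1nc2c3ccccc3ccc2c2nc3c(ccc4ccccc43)c(-c3cc([N+](=O)[O-])ccc3N)c12` gives 110 ug/mL in this assay; the gaps to these two are within the scatter, so no order among the three can be claimed. Compound 4 `Cc1nc2c3ccccc3ccc2c2nc3c(ccc4ccccc43)c(-c3ccccc3)c12` differs from compound 3 by phenyl in place of methyl on an aromatic carbon. The measured steps that bear on this change are those in which methyl replaced an aromatic ring at the same place: a 1.2-fold higher number from compound 2 to compound 3 (0.09 log units; within the scatter) and a 1.8-fold higher number from compound 1 to compound 3 (0.25 log units; within the scatter), both within the scatter. A ring carrying no further group has not been measured; each measured ring carried a nitro group, one of them also an amino group. On this basis no step beyond the scatter is expected; the estimate amounts to a 1.2-fold lower number from compound 3 to compound 4 (0.09 log units; within the scatter), a slightly lower number. Compound 4 is expected to give 160 ug/mL in this assay, with a range from 90 ug/mL to 290 ug/mL.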

Compound 4, half-maximal inhibitory concentration: 188 ug/mL
The estimate for compound 4 lay 1.2-fold (0.07 log units) below the measured number, and the stated range covers the measured number.
By their numbers in this assay, from the lowest: compounds 1, 2, 4 and 3 (each within the scatter of the next).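

In this assay, for the compounds shown here, phenyl in place of methyl on the aromatic carbon opposite the ring nitrogen is the first reading for a ring carrying no further group, and the step stays within the scatter (a 1.0-fold lower number from compound 3 to compound 4 (0.02 log units; within the scatter)). Hydrogen in place of nitro (a 1.2-fold higher number from compound 2 to compound 4 (0.08 log units; within the scatter)) and phenyl in place of 2-amino-5-nitrophenyl (a 1.7-fold higher number from compound 1 to compound 4 (0.23 log units; within the scatter)) also stay within it, so no step among these four compounds, with or without groups on the ring, lies beyond the scatter. No data here explain this flat picture.

Open, going by these compounds, is whether any group at this position gives a step beyond the scatter, such as a carboxylic acid on the phenyl ring or a longer alkyl chain in place of methyl. Also open, on these data alone, is how a phenyl ring carrying amino without nitro would read.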